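The source may hold more compounds than are shown below. What is called first, only, known or untested is meant among the compounds shown, and "the series" means these compounds.

Measured so far in a physicochemical assay for lipophilicity, at pH 7.4; a lower number here means a more polar compound, a higher number a more lipophilic compound
compound 1 `O=C(NCc1ccc(Cl)cc1)c1ncc2ccccc2c1O` gives 7.6
compound 2 `O=C(NCc1ccc(F)cc1)c1ncc2c(N3CCCCS3(=O)=O)cccc2c1O` gives "not determined" (no result reported)

In this assay compound 2 has no number, its entry reading ("not determined" (no result reported)), so it cannot be placed relative to compound 1. Compound 3 `O=C(NCc1ccc(F)cc1)c1ncc2c(NC3CCOCC3)cccc2c1O` has yet to be measured. The structural change is a group of 7 heavy atoms (5 carbon, 1 nitrogen, 1 oxygen; one six-membered non-aromatic ring with 1 hetero atom) in place of a group of 8 heavy atoms (4 carbon, 1 nitrogen, 2 oxygen, 1 sulfur; one six-membered non-aromatic ring with 2 hetero atoms), on an aromatic carbon and puts an (oxan-4-yl)amino group on an aromatic carbon in place of the group of 8 heavy atoms. Among the measured compounds shown here, no measured step shows what such an exchange does, and compound 2 offers no starting value. For the measured compounds named here, the only available anchor is compound 1 (7.6), so no step beyond the scatter is expected from that value, with neither direction favoured. With so little data, the expected range is kept wide. Compound 3 is estimated at 7.6 with an expected range from 6.8 to 8.4 on this scale.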

Compound 3, distribution coefficient: 5.3
The estimate for compound 3 lay 2.30 log units above the measured number; the whole stated range lies above it.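

Compound 2 has no number in this assay and so compound 3 at 5.3 cannot be set against it, and no step can be read. Nothing available bears on this result. The compounds shown leave open what placing (oxan-4-yl)amino on the shared core does to this read-out.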